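This account rests on a few compounds, and the source may have more. Where it says the series, first, only, none or still open, it means among the compounds named here.

Working notes on the series.

Compound 3 `CN(C(=O)NC(=O)c1cccc(C(F)(F)F)c1)c1nc(C(F)(F)F)c(C(=O)N/N=C/c2cc(C(F)(F)F)cc(C(F)(F)F)c2)s1` sits second highest of the three numbers measured in a functional assay on A549 cells (Homo sapiens) for inhibition, read by MTT assay, with a stated time of 72 h (on this read-out lower numbers stand for stronger inhibition and higher numbers for weaker inhibition), where compound 3 gives 8.2 ug/mL. Its nearest neighbour is compound 1 `CN(C(=O)NC(=O)c1cccc(C(F)(F)F)c1)c1nc(C(F)(F)F)c(C(=O)N/N=C/c2ccccc2C(F)(F)F)s1`, which in this assay gives 12.1 ug/mL; the gap between the two lies within the scatter. Among the compounds with values here, compound 2 `CN(C(=O)NC(=O)c1ccccc1F)c1nc(C(F)(F)F)c(C(=O)N/N=C/c2cc(C(F)(F)F)cc(C(F)(F)F)c2)s1` gives 5.43 ug/mL, and the only step charted within one place, a 1.5-fold higher number from compound 2 to compound 3 (0.18 log units; within the scatter), is a change at the carbonyl carbon that also stays within the scatter.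

Compound 4 `CN(C(=O)NC(=O)c1cccc(C(F)(F)F)c1)c1nc(C(F)(F)F)c(C(=O)N/N=C/c2cccc(C(F)(F)F)c2)s1` is not yet measured. The change from compound 3 is hydrogen in place of trifluoromethyl on an aromatic carbon: on the six-membered aromatic ring of carbon only, meta to a trifluoromethyl group, one trifluoromethyl gives way to hydrogen. Within the data shown here, no measured step touches this ring on its own; compound 1 and compound 3 carry different substitution there but also differ elsewhere, and their two values lie within the scatter of each other. Among the measured compounds shown here, the single step that exists, from compound 2 to compound 3, sits on a different ring and was itself within the scatter. No step beyond the scatter is therefore expected in this assay, in either direction.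

Compound 4 is estimated at 9 ug/mL, with a range of 4 ug/mL to 20 ug/mL, which means an expected step of a 1.1-fold higher number from compound 3 to compound 4 (0.04 log units; within the scatter).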

Compound 4, half-maximal inhibitory concentration: 8.16 ug/mL
Beside the measured number, compound 4's estimate is 1.1-fold (0.04 log units) above it; the range from low to high includes it.
By their numbers in this assay, from the lowest: compounds 2, 4, 3 and 1 (each within the scatter of the next, the first and the last beyond it).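

In this assay, within the data shown here, a 1.0-fold lower number from compound 3 to compound 4 (0.00 log units; within the scatter) gives the first reading of this ring in which only one place differs: at this position, meta to a trifluoromethyl group, hydrogen and trifluoromethyl are not told apart in this assay. A second single-place reading on the same ring, a 1.5-fold lower number from compound 1 to compound 4 (0.17 log units; within the scatter), shows that 3-(trifluoromethyl)phenyl in place of 2-(trifluoromethyl)phenyl on a carbon with a double bond to nitrogen also stays within the scatter, so neither change to this ring gives a step beyond it. No measurement of any other kind bears on these readings, and they remain numbers without an explanation.

On these data alone, both steps concern hydrogen or trifluoromethyl on this ring, so it remains open whether an amine or a carboxylic acid at the same position would stay within the scatter or give a clear step. As far as these compounds go, both steps also share the 3-(trifluoromethyl)phenyl group on the carbonyl carbon, and it remains open whether they would read the same with the 2-fluorophenyl group of compound 2 there.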